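This account rests on a few compounds, and the source may have more. Where it says the series, first, only, none or still open, it means among the compounds named here.

The series shares one core and varies only the aryl group on the aromatic nitrogen. Compound 1 is `N#CC1=C(N)Oc2c(c3nc4ccccc4nc3c3ccccc23)C12C(=O)N(Cc1cnnn1-c1ccc(F)cc1)c1ccccc12`. In a functional assay on A549 cells (Homo sapiens) for antiproliferative activity, read by MTT assay, with a stated time of 48 h (on this read-out lower numbers stand for stronger inhibition and higher numbers for weaker inhibition), compound 1 gives only a limit, > 50000 nM. Compound 2, `N#CC1=C(N)Oc2c(c3nc4ccccc4nc3c3ccccc23)C12C(=O)N(Cc1cnnn1-c1ccccc1Br)c1ccccc12`, likewise gives only a limit in this assay, > 50000 nM. Compound 3, `COc1ccccc1-n1nncc1CN1C(=O)C2(C(C#N)=C(N)Oc3c2c2nc4ccccc4nc2c2ccccc32)c2ccccc21`, also gives only a limit in this assay, > 50000 nM. All three sit at the limit of > 50000 nM in this assay, at which 3 of the 3 values shown sit, so none of the steps among them can be read: a step that the two limits leave unreadable from compound 1 to compound 2, a step that the two limits leave unreadable from compound 1 to compound 3, and a step that the two limits leave unreadable from compound 2 to compound 3. Compound 3 therefore stands at the limit, indistinguishable on these numbers from the other two.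

Compound 4 is `CCOc1ccc(-n2nncc2CN2C(=O)C3(C(C#N)=C(N)Oc4c3c3nc5ccccc5nc3c3ccccc43)c3ccccc32)cc1`. It differs from compound 3 by 4-ethoxyphenyl in place of 2-methoxyphenyl on an aromatic nitrogen. The measured steps that bear on it are the two other exchanges of the aryl group on the aromatic nitrogen, a step that the two limits leave unreadable from compound 1 to compound 3 and a step that the two limits leave unreadable from compound 2 to compound 3, both unreadable. For the measured compounds named here, no step in this assay is readable, so no direction and no size can be derived from the data; an outcome at the limit is the plainest expectation. Compound 4 is therefore expected to give 70000 nM in this assay. The expected range for compound 4 runs from 20000 nM to 300000 nM. The expected step is a step that the limit leaves unreadable from compound 3 to compound 4, which the limit would most likely again leave unreadable.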

Compound 4, half-maximal inhibitory concentration: 25200 nM
For compound 4 the middle estimate is 2.8-fold (0.44 log units) above the measured one; low and high end bracket the measured number.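

In this assay compound 4 gives 25200 nM, the only number in the set rather than a limit: the limit of > 50000 nM in this assay, at which 3 of the 4 values shown sit.

The aryl group on the aromatic nitrogen can therefore bring the read-out within measurable range, as seen in an at least 1.9-fold lower number from compound 3 to compound 4 (0.29 log units; that floor lies within the scatter), an at least 1.9-fold lower number from compound 2 to compound 4 (0.29 log units; that floor lies within the scatter) and an at least 1.9-fold lower number from compound 1 to compound 4 (0.29 log units; that floor lies within the scatter), but each of these is only a floor, and the true sizes cannot be read. The step from compound 1 is the narrowest exchange, ethoxy in place of fluoro on an aromatic carbon with the 4-substituted phenyl kept, whereas the steps from compound 2 and compound 3 also change where the substituent sits on the phenyl ring, and the steps among compound 1, compound 2 and compound 3 cannot be read.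

With a single measured number, the compounds shown do not separate the effect of the ethoxy group from that of its 4-placement, and 2-ethoxyphenyl or 4-methoxyphenyl would be needed to do so. From the compounds shown here alone, whether a longer chain such as 4-propoxyphenyl, or an amine such as 4-aminophenyl, would give a number beyond the scatter also remains open.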